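This account rests on a few compounds, and the source may have more. Where it says the series, first, only, none or still open, it means among the compounds named here.

Measured so far:
compound 1, `CNC(=O)c1ccccc1-c1ccc(CNc2ncccc2NC(=O)CC(F)(F)F)cc1`: 33 nM
compound 2, `COC(=O)c1ccccc1-c1ccc(CNc2nccc(C)c2NC(=O)CC(F)(F)F)cc1`: 7.1 nM

Of the compounds shown here, two have been measured in an in vitro assay on CHO cells for inhibition of B1 bradykinin receptor (Homo sapiens); a lower number here means a stronger inhibitor, a higher number a weaker inhibitor. Compound 1 gives 33 nM in this assay, while compound 2 gives 7.1 nM, the lower of the two numbers, and the gap between them lies beyond the usual scatter of this assay. Compound 1 and compound 2 differ in more than one place, so their two values alone do not separate the contributions of those differences.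

Compound 3, `CNC(=O)c1ccccc1-c1ccc(CNc2nccc(C)c2NC(=O)CC(F)(F)F)cc1`, has not yet been measured. It differs from compound 2 by methylamino in place of methoxy on a carbonyl carbon. Within the data shown here, since no single step of this kind is available among the measured compounds, the expected step is judged to be small: compound 3 is estimated at 12 nM in this assay, with a plausible range from 4 nM to 35 nM. That estimate corresponds to an expected change of a 1.7-fold higher number from compound 2 to compound 3 (0.23 log units; within the scatter), which may well fall within the scatter.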

Compound 3, inhibition constant: 11 nM
Estimate against measurement, compound 3: 1.1-fold (0.04 log units) above; measured number inside the range.
By their numbers in this assay, from the lowest: compounds 2 and 3 (each within the scatter of the next); then compound 1.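

In this assay, methylamino in place of methoxy on a carbonyl carbon gives a 1.5-fold higher number from compound 2 to compound 3 (0.19 log units; within the scatter), so this read-out does not tell the two groups apart at this carbonyl. Compound 3 also separates the two differences that were mixed in the first pair: methyl in place of hydrogen on an aromatic carbon gives a 3.0-fold lower number from compound 1 to compound 3 (0.48 log units; beyond the scatter), a modest step. Of the two single changes, only this one lies beyond the scatter.

From the compounds shown here alone, whether the carbonyl carbon would accept a carboxylic acid or a dimethylamino group in the same way remains open, as does whether an ethyl group or chlorine on that aromatic carbon would match methyl. Nothing at hand bears on why these steps have the sizes they do.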